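This account rests on a few compounds, and the source may have more. Where it says the series, first, only, none or still open, it means among the compounds named here.

Compound 1 `COC(=O)/C=C/c1cccc(N(Cc2ccc(-c3cccc(Cl)c3)cc2)C(=O)C2CCCCC2)c1`: 94 nM
Compound 2 `COC(=O)/C=C/c1cccc(N(Cc2ccc(/C=C/C(=O)OCc3ccccc3)cc2)C(=O)C2CCCCC2)c1`: > 1000 nM

In an assay on isolated protein with Bile acid receptor (Homo sapiens) as the target (a higher number here means that more compound is needed for the effect, a lower number that less compound is needed), compound 1 gives 94 nM. Compound 2 gives only a limit, > 1000 nM. Compound 2 thus sits at the limit of > 1000 nM in this assay, at which 1 of the 2 values shown sits. Compound 3 `COC(=O)/C=C/c1cccc(N(Cc2ccc(-c3cc(Cl)ccc3OC)cc2)C(=O)C2CCCCC2)c1` differs from compound 2 by 5-chloro-2-methoxyphenyl in place of 2-(benzyloxycarbonyl)ethenyl on an aromatic carbon. Going by the values given here, the one measured step bearing on this is an at least 10-fold higher number from compound 1 to compound 2 (1.02 log units; beyond the scatter), the same kind of exchange in the opposite direction. Compound 3 carries a group of the same kind as the 3-chlorophenyl of compound 1. For compound 3 a step of an at least 6.6-fold lower number from compound 2 to compound 3 (0.82 log units; beyond the scatter) is therefore expected. Compound 3 is estimated at 150 nM, with a range from 40 nM to 600 nM.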

Compound 3, half-maximal effective concentration: 233 nM
Compound 3: the middle estimate sits 1.6-fold (0.19 log units) below what was measured; low and high end bracket the measured number.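

Replacing the 2-(benzyloxycarbonyl)ethenyl with 5-chloro-2-methoxyphenyl gives an at least 4.2-fold lower number from compound 2 to compound 3 (0.63 log units; beyond the scatter), so a second chlorine-bearing aromatic ring at this place brings back a measurable value. The size of that step is open-ended, as compound 2 stands only at a limit: the limit of > 1000 nM in this assay, at which 1 of the 3 values shown sits. Adding methoxy to the ring of compound 1 gives a 2.5-fold higher number from compound 1 to compound 3 (0.39 log units; beyond the scatter), so substitution on this ring also moves the number.

As far as these compounds go, it remains open whether a hydroxyl or an amine in place of that methoxy would behave alike, and whether the chlorine is needed at all.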